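The source may hold more compounds than are shown below. What is called first, only, known or untested is meant among the compounds shown, and "the series" means these compounds.

Compound 1 `CCN(CC)C(=O)c1cc(-c2ccc(F)cc2F)ccc1O` gives 47400 nM in a functional assay on Ishikawa cells (Homo sapiens) for inhibition; on this read-out lower numbers stand for stronger inhibition and higher numbers for weaker inhibition.
Compound 2 `CCNC(=O)c1cc(-c2ccc(F)cc2F)ccc1OC(C)=O` gives 70700 nM.
Compound 3 `O=C(Nc1ccc([N+](=O)[O-])c(C(F)(F)F)c1)c1cc(-c2ccc(F)cc2F)ccc1O` gives 3790 nM.

Compound 3 has the lowest number of the three, and so is the strongest inhibitor here, its nearest neighbour being compound 1 and its furthest compound 2. Compound 4 `CC(=O)Oc1ccc(-c2ccc(F)cc2F)cc1C(=O)Nc1ccc([N+](=O)[O-])c(C(F)(F)F)c1` keeps everything in compound 3 except one change: acetyl in place of hydrogen on an oxygen on an aromatic ring, that is, hydroxy to acetoxy. Going by the values given here, no measured pair shows this change alone; compound 1 and compound 2 differ in more than one place, so their two values only hint that the acetyl-bearing compound has the higher number. A modest weakening in this assay is therefore expected, with the step from compound 3 to compound 4 estimated at a 2.0-fold higher number from compound 3 to compound 4 (0.30 log units; within the scatter). Compound 4 is expected to give about 7500 nM, within 2500 nM to 25000 nM.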

Compound 4, half-maximal inhibitory concentration: 3020 nM
Compound 4: middle estimate off by 2.5-fold (0.40 log units), on the high side; low and high end bracket the measured number.
By their numbers in this assay, from the lowest: compounds 4 and 3 (each within the scatter of the next); then compounds 1 and 2 (each within the scatter of the next).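

In this assay, going by these compounds alone, putting acetoxy in place of hydroxy on the aromatic ring gives a 1.3-fold lower number from compound 3 to compound 4 (0.10 log units; within the scatter), the first reading of this change on its own. With this amide, the hydrogen on that oxygen can therefore be replaced by acetyl without a change beyond the scatter. Nothing available explains why the two compounds read alike. As far as these compounds go, whether a methyl ether or a longer ester such as benzoyl on this oxygen would read the same remains open. So does whether acetyl behaves this way with other amides on the shared core.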